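Serine- and aspartate-derived esters as N-type calcium channel blockers

The source may report more compounds than this note shows. Statements on the series, on what has been measured and on what is new or still open speak of the compounds shown alone.

Measured so far:
compound 1 `COc1ccc(COC(=O)[C@@H](CC(=O)OC2CCCC2)NC(=O)OC(C)(C)C)cc1`: 2000 nM
compound 2 `COc1ccc(COC(=O)[C@H](COC(=O)C2CCCCC2)NC(=O)OC(C)(C)C)cc1`: 1600 nM

In a functional assay on IMR-32 cells for inhibition of Voltage-dependent N-type calcium channel subunit alpha-1B (Homo sapiens), read by calcium flux (a lower number here means a stronger inhibitor, a higher number a weaker inhibitor), compound 2 gives 1600 nM, and compound 1 gives 2000 nM; the two numbers lie within the usual scatter of each other, so neither stands apart. Compound 3 `COc1ccc(COC(=O)[C@H](CC(=O)OC2CCCCC2)NC(=O)OC(C)(C)C)cc1` is not yet measured. Relative to compound 2 it carries cyclohexyloxycarbonyl in place of (cyclohexylcarbonyl)oxy on a saturated chain carbon, two bonds along the chain from an amide-type nitrogen and a carbonyl carbon. The ester is thus turned round, bringing compound 3 close to compound 1, whose value is of the same order as that of compound 2. No change beyond the scatter is expected for the step of a 1.1-fold higher number from compound 2 to compound 3 (0.05 log units; within the scatter). Compound 3 is estimated at 1800 nM, between 900 nM and 3600 nM.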

Compound 3, half-maximal inhibitory concentration: 2300 nM
For compound 3 the middle estimate is 1.3-fold (0.11 log units) below the measured one; measured number inside the range.
By their numbers in this assay, from the lowest: compounds 2, 1 and 3 (each within the scatter of the next).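

In this assay the ester at this position can be turned round, with cyclohexyloxycarbonyl in place of (cyclohexylcarbonyl)oxy, and the result is a 1.4-fold higher number from compound 2 to compound 3 (0.16 log units; within the scatter) and no more. With the same atoms joined differently, the direction of the ester linkage on this saturated chain carbon does not separate the two compounds. Nothing available bears on why this is so.

In this assay the compounds shown leave open how a carboxylic acid or an amine at this position would read, and likewise a longer chain carrying the cyclohexyl ester.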